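A few compounds are considered here, and "the series" means these few. Any claim that something is new, unique, unknown or untested is made for them only; others in the source may bear on it.

Measured so far:
compound 1, `COc1ccc(C(=O)N2N=C(C)CC2c2ccccc2O)cc1`: 40300 nM
compound 2, `CC1=NN(S(=O)(=O)c2ccccc2C)C(c2cc(Br)ccc2O)C1`: 39300 nM

In a functional assay on HepG2 cells (Homo sapiens) for antiproliferative activity, read by MTT assay, with a stated time of 48 h (a lower number here means that less compound is needed, a higher number that more compound is needed for the effect), compound 2 gives 39300 nM. Compound 2 stands alongside compound 1, the gap between the two numbers lying within the scatter, so neither can be set apart from the other on these data. Compound 3 `CC1=NN(S(=O)(=O)c2ccc(Cl)cc2)C(c2cc(Br)ccc2O)C1` is unmeasured; it differs from compound 2 by 4-chlorophenyl in place of 2-methylphenyl on a sulfonyl sulfur. Going by the values given here, no step between measured compounds bears on this change, so nothing beyond the scatter is expected in this assay from compound 2 to compound 3, in either direction. For compound 3 the estimate in this assay is 36000 nM, with a range from 12000 nM to 110000 nM, a step of a 1.1-fold lower number from compound 2 to compound 3 (0.04 log units; within the scatter) that is expected to fall within the scatter.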

Compound 3, half-maximal effective concentration: > 60000 nM
Compound 3: a limit, no number; the forecaster's own chance of this, stated with the estimate: 10%; middle value at least 1.6-fold (0.22 log units) away from the limit.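

In this assay compound 3 gives > 60000 nM, which is a limit of the assay and not a number. Going by these compounds alone, the only step read on the sulfonyl sulfur, 4-chlorophenyl in place of 2-methylphenyl, gives an at least 1.5-fold higher number from compound 2 to compound 3 (0.18 log units; that floor lies within the scatter), so the change has a floor but no known size. The comparison stays open-ended: the limit of > 60000 nM in this assay, at which 1 of the 3 values shown sits.

Still open, on these data alone, is whether 4-chlorophenyl or the departure of 2-methylphenyl carries the step, which plain phenyl on the sulfonyl sulfur would help separate. As far as these compounds go, how an aliphatic amine at this place would read also remains open.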